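The compounds below may be only part of what the source reports. "The series", "measured", "known", "first", "only" and "open" are said of these compounds alone.

Measured compounds in a functional assay on T-24 cells (Homo sapiens) for antiproliferative activity, read by MTT assay, with a stated time of 48 h; on this read-out higher numbers stand for weaker inhibition and lower numbers for stronger inhibition:
Compound 1 `O=C(Nc1cccc(CNc2nccnc2Cl)c1)Nc1ccccc1Cl` gives 6680 nM.
Compound 2 `O=C(Nc1ccccc1)Nc1cccc(CNc2nccnc2Cl)c1` gives 19800 nM.
Compound 3 `O=C(Nc1cccc(CNc2nccnc2Cl)c1)NC1CCCCC1` gives > 40000 nM, which is a limit of the assay rather than a number.

Compound 3 therefore stands at the limit of > 40000 nM in this assay, at which 1 of the 3 values shown sits, with no number of its own. Compound 4 `O=C(Nc1cccc(CNc2nccnc2Cl)c1)Nc1ccc(Cl)cc1Br` differs from it in one place: 2-bromo-4-chlorophenyl in place of cyclohexyl on an amide-type nitrogen. Among the compounds with values here, two measured steps bear on this change, read in reverse: an at least 5.9-fold higher number from compound 1 to compound 3 (0.77 log units; beyond the scatter) and an at least 2.0-fold higher number from compound 2 to compound 3 (0.30 log units; that floor lies within the scatter). Putting an aromatic ring back in place of the cyclohexyl is thus expected to lower the number in this assay, at least modestly, and the 2-bromo-4-chlorophenyl of compound 4 resembles the 2-chlorophenyl of compound 1 more than the phenyl of compound 2. Near the value of compound 1, compound 4 is expected to give 7000 nM (range 2500 nM to 25000 nM), an estimated step of an at least 5.7-fold lower number from compound 3 to compound 4 (0.75 log units; beyond the scatter).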

Compound 4, half-maximal inhibitory concentration: 6650 nM
Estimate against measurement, compound 4: 1.1-fold (0.02 log units) above; the range from low to high includes it.
By their numbers in this assay, from the lowest: compounds 4 and 1 (each within the scatter of the next); then compound 2. At a limit, above all of these: compound 3.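

Placing 2-bromo-4-chlorophenyl on the amide-type nitrogen in place of cyclohexyl gives an at least 6.0-fold lower number from compound 3 to compound 4 (0.77 log units; beyond the scatter), and in place of phenyl it gives a 3.0-fold lower number from compound 2 to compound 4 (0.47 log units; beyond the scatter). In place of 2-chlorophenyl it gives a 1.0-fold lower number from compound 1 to compound 4 (0.00 log units; within the scatter), so the ring carrying both bromo and chloro cannot be told apart here from the ring carrying chloro alone. The reading for compound 3 is a limit and not a number: the limit of > 40000 nM in this assay, at which 1 of the 4 values shown sits.

As far as these compounds go, how a phenyl ring carrying a methoxy, an amine or a carboxylic acid would read on this nitrogen remains open. So does a small chain such as methyl or ethyl.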